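Swapping a branched chain for a methoxy-bearing ether

This account rests on a few compounds, and the source may have more. Where it says the series, first, only, none or still open, it means among the compounds named here.

Of the compounds shown here, three sharing one core have been measured in an ADME assay on HepG2 cells (Homo sapiens) for cytotoxicity, read by luminescence, CellTiter-Glo and ATP content, with a stated time of 72 h; a higher number here means that more compound is needed for the effect, a lower number that less compound is needed. Compound 1 `CC(C)(C)c1ccc(Oc2ccc3c(NCCCNCc4ccco4)ccnc3c2)cc1` gives 3100 nM. Compound 2 `c1ccc(Oc2ccc3c(NCCCNCc4ccco4)ccnc3c2)cc1` gives 15200 nM, and compound 3 `CCC(CC)c1ccc2c(NCCCNCc3ccco3)ccnc2c1` gives 6760 nM, the second highest of the three numbers. The measured steps were a 4.9-fold higher number from compound 1 to compound 2 (0.69 log units; beyond the scatter) and a 2.2-fold lower number from compound 2 to compound 3 (0.35 log units; beyond the scatter). Compound 4 `COc1ccccc1Oc1ccc2c(NCCCNCc3ccco3)ccnc2c1` is not yet measured; it differs from compound 3 by 2-methoxyphenoxy in place of pentan-3-yl on an aromatic carbon. The step from compound 2 to compound 3 bears on this change most directly, since it exchanged a phenoxy group for the same chain, and the step from compound 1 to compound 2 shows that a group on that phenoxy ring can shift the number. The change is therefore expected to raise the number, the expected step being a 1.5-fold higher number from compound 3 to compound 4 (0.17 log units; within the scatter). Compound 4 is expected to give 10000 nM in this assay, within 4000 nM to 25000 nM.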

Compound 4, half-maximal effective concentration: 6500 nM
For compound 4 the middle estimate is 1.5-fold (0.19 log units) above the measured one; the range from low to high includes it.
By their numbers in this assay, from the lowest: compound 1; then compounds 4 and 3 (each within the scatter of the next); then compound 2.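

With a 1.0-fold lower number from compound 3 to compound 4 (0.02 log units; within the scatter) there is no telling 2-methoxyphenoxy from pentan-3-yl at this position in this assay on these numbers. Methoxy on the phenoxy ring does count, with a 2.3-fold lower number from compound 2 to compound 4 (0.37 log units; beyond the scatter) and then a 2.1-fold higher number from compound 1 to compound 4 (0.32 log units; beyond the scatter) as the change to the 2-methoxyphenyl ether, so both groups on that ring lower the number relative to compound 2, tert-butyl by more. No data at hand give a reason for these shifts.

As far as these compounds go, whether an amine or a carboxylic acid on that phenoxy ring would shift the number stays open. So does whether methoxy would act the same elsewhere on that ring.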